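Changing the Amine at the End of the Chain

The source may hold more compounds than are shown below. What is called first, only, known or untested is meant among the compounds shown, and "the series" means these compounds.

In a functional assay on DU-145 cells (Homo sapiens) for antiproliferative activity, read by WST assay, with a stated time of 3 days (a lower number here means a stronger inhibitor, a higher number a weaker inhibitor), compound 1 `CCOc1c(-c2cc(OC)c(OC)c(OC)c2)oc2ccccc2c1=O` gives 6200 nM. Compound 2 `CCCCCCCOc1c(-c2cc(OC)c(OC)c(OC)c2)oc2ccccc2c1=O` gives > 50000 nM, which is a limit of the assay and not a number. Compound 3 `CCCN(CCC)CCCCOc1c(-c2cc(OC)c(OC)c(OC)c2)oc2ccccc2c1=O` gives 35800 nM, the higher of the two exact numbers in the set.

Compound 4 `CCCCCN(CCCCC)CCCOc1c(-c2cc(OC)c(OC)c(OC)c2)oc2ccccc2c1=O` has not yet been measured. It differs from compound 3 by dipentylamino in place of (dipropylamino)methyl on a saturated chain carbon, three bonds along the chain from an oxygen on an aromatic ring.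

Going by the values given here, three measured steps bear on this change. Two start from compound 1 and add a longer group, and both raise the number: an at least 8.0-fold higher number from compound 1 to compound 2 (0.90 log units; beyond the scatter) and a 5.8-fold higher number from compound 1 to compound 3 (0.76 log units; beyond the scatter). The third exchanges propyl for dipropylamino at the chain end and gives an at least 1.3-fold lower number from compound 2 to compound 3 (0.14 log units; that floor lies within the scatter), so it shows no firm change. Compound 3 already carries a long amine-bearing chain, and the swap to compound 4 keeps the amine while altering its chains. No step beyond the usual scatter is therefore expected, and the estimate means a 1.4-fold lower number from compound 3 to compound 4 (0.16 log units; within the scatter). Compound 4 is expected to give about 25000 nM, within an estimated range of 8000 nM to 60000 nM.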

Compound 4, half-maximal inhibitory concentration: 12300 nM
Compound 4: the middle estimate sits 2.0-fold (0.31 log units) above what was measured; low and high end bracket the measured number.
By their numbers in this assay, from the lowest: compounds 1 and 4 (each within the scatter of the next); then compound 3. At a limit, above all of these: compound 2.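

In this assay, going by these compounds alone, the swap at the chain end gives the first change beyond the scatter between two compounds that both carry an amine: a 2.9-fold lower number from compound 3 to compound 4 (0.46 log units; beyond the scatter), so the groups on the nitrogen and the length of the chain that holds it do matter at this position. Compound 4 also shows that a long chain ending in an amine can come close to the short chain of the first compound, since a 2.0-fold higher number from compound 1 to compound 4 (0.30 log units; within the scatter) stays within the scatter, while an at least 4.0-fold lower number from compound 2 to compound 4 (0.60 log units; beyond the scatter) sets it clearly apart from the amine-free heptyl-type chain. That second comparison has a floor and not an exact size, as compound 2 gives a limit and not a number: the limit of > 50000 nM in this assay, at which 1 of the 4 values shown sits.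

The change from compound 3 to compound 4 alters the length of the chain and the groups on the nitrogen together, so the compounds shown cannot say which of the two accounts for the step. Going by these compounds, how a ring amine such as piperidine or morpholine, or a smaller dimethylamino group, would behave at the end of this chain remains open.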